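The compounds below may be only part of what the source reports. "The series", "measured", "known", "first", "only" and "open" are said of these compounds alone.

Measured so far in an ADME assay on cells (Hepatocyte, Mus musculus) for metabolic stability, with a stated time of 30 min; a higher number here means that more of the compound is left, a lower number that less of the compound is left:
- compound 1 `O=C(OC1CCC(CN2CCN(c3cc(=O)c4cc(C(F)(F)F)cc([N+](=O)[O-])c4s3)CC2)CC1)c1ccccc1`: 68.1%
- compound 2 `CS(=O)(=O)NC1CCC(CN2CCN(c3cc(=O)c4cc(C(F)(F)F)cc([N+](=O)[O-])c4s3)CC2)CC1`: 111%
- compound 3 `Cc1ccc(C(=O)OC2CCC(CN3CCN(c4cc(=O)c5cc(C(F)(F)F)cc([N+](=O)[O-])c5s4)CC3)CC2)cc1`: 18%

Compound 2 stands highest of the three numbers; its nearest neighbour is compound 1, with a number 42.9 percentage points higher from compound 1 to compound 2 (beyond the scatter), and the furthest is compound 3, with a number 93 percentage points lower from compound 2 to compound 3 (beyond the scatter). Both steps lie beyond the scatter.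

The next compound is compound 4 `O=C(OC1CCC(CN2CCN(c3cc(=O)c4cc(C(F)(F)F)cc([N+](=O)[O-])c4s3)CC2)CC1)c1ccc(F)cc1`. It differs from compound 2 as follows: ((4-fluorophenyl)carbonyl)oxy in place of methanesulfonamido on a saturated ring carbon. For the measured compounds named here, the step that bears on it most directly is the one from compound 2 to compound 3, where ((4-methylphenyl)carbonyl)oxy in place of methanesulfonamido gave a number 93 percentage points lower from compound 2 to compound 3 (beyond the scatter). Also relevant is the benzoyloxy compound 1, which sits between compound 2 and compound 3 in this assay, and the step from compound 1 to compound 3, a number 50.1 percentage points lower from compound 1 to compound 3 (beyond the scatter), showing that a substituent on the aromatic ring of the ester can move the number a long way. Going by the values given here, the fluorine of compound 4 has no measured counterpart here, so the step is expected to be a large downward one, with wide uncertainty in its size.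

Estimated for compound 4: a number 61 percentage points lower from compound 2 to compound 4 (beyond the scatter), giving 50% with a range of 20% to 80% in this assay.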

Compound 4, percent of the compound remaining: 1.5%
The estimate for compound 4 lay 48.5 percentage points above the measured number; measured number below the stated range.
By their numbers in this assay, from the lowest: compound 4; then compound 3; then compound 1; then compound 2.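

In this assay, the ((4-fluorophenyl)carbonyl)oxy group in place of methanesulfonamido on the saturated ring carbon gives a number 109.5 percentage points lower from compound 2 to compound 4 (beyond the scatter), the largest step seen at this position. On the aromatic ring of the ester, fluoro in place of hydrogen gives a number 66.6 percentage points lower from compound 1 to compound 4 (beyond the scatter), and fluoro in place of methyl gives a number 16.5 percentage points lower from compound 3 to compound 4 (beyond the scatter), so both ring-substituted esters stand lower than the benzoyloxy compound 1, with fluoro lowest of the series. No measured information on the cause of these shifts is available here.

The compounds shown leave open whether the ester link or the aromatic ring carries the difference from methanesulfonamido; a benzamide at the same ring carbon would separate the two. Also open, as far as these compounds go, is how a chloro or methoxy group on the aromatic ring would compare with fluoro and methyl.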